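Bromo to iodo swap on the shared core

The source may report more compounds than this note shows. Statements on the series, on what has been measured and on what is new or still open speak of the compounds shown alone.

Measured so far:
compound 1, `C[C@H](Nc1nc(-c2ccccc2)nc2ccc(Br)cc12)C(=O)O`, gives 0% in a functional assay on the whole organism (strain Wistar) for inhibition, with Rattus norvegicus as the target, read by paw edema, at a dose of 100 mg/kg by the oral route; a lower number here means less inhibition, a higher number more inhibition at the dose given (going by the name of the read-out).
compound 2, `C[C@H](Nc1nc(-c2ccccc2)nc2ccc(I)cc12)C(=O)O`, gives 6.5% in this assay.
compound 3, `CC[C@H](C)[C@H](Nc1nc(-c2ccccc2)nc2ccc(Br)cc12)C(=O)O`, gives 0% in this assay.

All three numbers sit low and close together. Compound 2 differs from compound 1 by iodo in place of bromo on an aromatic carbon; the step in this assay is a number 6.5 percentage points higher from compound 1 to compound 2 (within the scatter). Compound 3 differs from compound 1 by sec-butyl in place of methyl on a saturated chain carbon bound to a carbonyl carbon and a nitrogen on an aromatic ring; the step in this assay is no change at the digits printed from compound 1 to compound 3 (within the scatter). Going by the values given here, compound 3 thus stands level with compound 1 at the digits printed, and no compound here can be said to have a higher or lower number than another, since every step between them lies within the scatter.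

Compound 4, `CC[C@H](C)[C@H](Nc1nc(-c2ccccc2)nc2ccc(I)cc12)C(=O)O`, is not yet measured. It differs from compound 3 by iodo in place of bromo on an aromatic carbon. This is the same change as that made from compound 1 to compound 2, the two place descriptions agreeing word for word, so among the compounds shown the change occurs twice. The two cores on which it is made differ by the sec-butyl in place of methyl already described, a difference that itself moved the read-out not at all at the digits printed.

Compound 4 is expected to give 5% in this assay, with a range from 0% to 15%, because the same change once made a number 6.5 percentage points higher from compound 1 to compound 2 (within the scatter) and the second core showed no shift of its own. The expected step is a number 5 percentage points higher from compound 3 to compound 4 (within the scatter), estimated to fall within the scatter like the earlier one. Nothing in the three measured compounds points to a larger move.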

Compound 4, a percentage reported as inhibition, in the whole organism at one dose (the size of the read-out at that dose, not a potency): 0%
The estimate for compound 4 lay 5 percentage points above the measured number, and the stated range covers the measured number.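

In this assay, iodo in place of bromo on the sec-butyl core gives no change at the digits printed from compound 3 to compound 4 (within the scatter), and the step does not differ from the one on the methyl core: the same change on two cores in this assay, a number 6.5 percentage points higher (within the scatter) from compound 1 to compound 2 and no change at the digits printed (within the scatter) from compound 3 to compound 4, 6.5 percentage points apart, within the scatter of two such steps. Sec-butyl in place of methyl, read on the iodo core, gives a number 6.5 percentage points lower from compound 2 to compound 4 (within the scatter), which likewise does not differ from the step on the bromo core: the same change on two cores in this assay, no change at the digits printed (within the scatter) from compound 1 to compound 3 and a number 6.5 percentage points lower (within the scatter) from compound 2 to compound 4, 6.5 percentage points apart, within the scatter of two such steps. Both changes thus carry between these two cores without a measurable difference, but every step among the four compounds lies within the scatter, so this agreement shows neither that either change has any effect on paw edema nor how the changes would carry on a core with a clearly higher reading.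

The compounds shown leave open whether any change at these two places can lift the read-out out of the scatter, for example a chloro group on the same aromatic carbon or a benzyl group on the saturated chain carbon. Also open, as far as these compounds go, is how a methyl ester or a primary amide in place of the carboxylic acid would read in this assay.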